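Removing a Pyrrolidinylmethoxy Group: What Compound 4 Should Show

The compounds below may be only part of what the source reports. "The series", "measured", "known", "first", "only" and "open" are said of these compounds alone.

Of the compounds shown here, three have been measured in a functional assay on MDA-MB-231 cells (Homo sapiens) for antiproliferative activity, read by MTT assay, with a stated time of 48 h; a lower number here means a stronger inhibitor, a higher number a weaker inhibitor. Compound 1 `C=CS(=O)(=O)N1CCN(c2ncnc3sc(-c4ccc(OC)nc4)cc23)CC1` gives 9270 nM, compound 2 `C=CS(=O)(=O)N1CCN(c2nc(OC[C@H]3CCCN3C)nc3sc(-c4ccc(OC)nc4)cc23)CC1` gives 3560 nM, and compound 3 `C=CS(=O)(=O)N1CCN(c2nc(OC[C@H]3CCCN3C)nc3sc(-c4ccc(N5CCN(C)CC5)cc4)cc23)[C@@H](C)C1` gives 2880 nM. Compounds 2 and 1 differ by hydrogen in place of (1-methylpyrrolidin-2-yl)methoxy on an aromatic carbon, and this change produced a 2.6-fold higher number from compound 2 to compound 1 (0.42 log units; beyond the scatter). The difference between the cores of compound 2 and compound 3 is not broken down here; their values lie within the scatter of each other.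

Compound 4 `C=CS(=O)(=O)N1CCN(c2ncnc3sc(-c4ccc(N5CCN(C)CC5)cc4)cc23)[C@@H](C)C1` has not yet been measured. It differs from compound 3 by hydrogen in place of (1-methylpyrrolidin-2-yl)methoxy on an aromatic carbon. This is the same kind of change as that from compound 2 to compound 1, though the place is meta to a 2-methyl-4-(vinylsulfonyl)piperazin-1-yl group in compound 3 rather than meta to a 4-(vinylsulfonyl)piperazin-1-yl group in compound 2. Given the earlier step of a 2.6-fold higher number from compound 2 to compound 1 (0.42 log units; beyond the scatter), compound 4 is expected to show a step of a 2.6-fold higher number from compound 3 to compound 4 (0.42 log units; beyond the scatter) in this assay, resting on compound 3 standing at 2880 nM. The estimate for compound 4 in this assay is 7500 nM, with a range from 3500 nM to 16000 nM.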

Compound 4, half-maximal inhibitory concentration: 6180 nM
Estimate against measurement, compound 4: 1.2-fold (0.08 log units) above; the range from low to high includes it.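

In this assay, replacing the (1-methylpyrrolidin-2-yl)methoxy group with hydrogen gave a 2.1-fold higher number from compound 3 to compound 4 (0.33 log units; beyond the scatter), so the number rose on this core as it had on the core of compound 2. The two steps can be set side by side and do not differ: the same change on two cores in this assay, a 2.6-fold higher number (0.42 log units; beyond the scatter) from compound 2 to compound 1 and a 2.1-fold higher number (0.33 log units; beyond the scatter) from compound 3 to compound 4, 1.2-fold (0.08 log units) apart, within the scatter of two such steps This shows that, for these two pairs, the change carried from one core to the other with its direction and size preserved, but it rests on two cores only and does not show that the same would hold on any other core, nor does it explain the step.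

The compounds shown leave open which part of the departing group accounts for the step, as the whole group gives way to hydrogen in both pairs. Going by these compounds, whether a plain methoxy, a 2-(dimethylamino)ethoxy chain or a pyrrolidinylmethoxy group without the N-methyl would hold the lower number at this carbon between two ring nitrogen atoms also remains open.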